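This account rests on a few compounds, and the source may have more. Where it says the series, first, only, none or still open, it means among the compounds named here.

Compound 1 `CNC(=O)c1cc(Oc2ccc3nc(Nc4ccccc4)ncc3c2)ccn1` — < 1000 nM
Compound 2 `CNC(=O)c1cc(Oc2ccc3nc(Nc4ccc(C(C)C)cc4)ncc3c2)ccn1` — < 1000 nM

In a physicochemical assay for solubility, at pH 7 (a higher number here means a more soluble compound, a lower number a less soluble compound), compound 1 gives < 1000 nM, which is a limit of the assay rather than a number. Compound 2 gives < 1000 nM in this assay, again a limit. The step that the two limits leave unreadable from compound 1 to compound 2 is therefore unreadable in size and direction. Where compound 2 stands is known only through (the limit of < 1000 nM in this assay, at which 2 of the 2 values shown sit), the point at which both measured compounds sit.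

Compound 3 `CNC(=O)c1cc(Oc2ccc3nc(Nc4ccc(OC)cc4)ncc3c2)ccn1` differs from compound 2 by methoxy in place of isopropyl on an aromatic carbon. Among the measured compounds shown here, the only measured step, that from compound 1 to compound 2, bears on it solely as a second case of the same limit, and gives no size to expect. With both measured values at the limit, compound 3 is expected to fall in the same region, with the step that the limit leaves unreadable from compound 2 to compound 3 estimated as no readable change, so that compound 3 is estimated at 500 nM, between 100 nM and 3000 nM.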

Compound 3, solubility: < 1000 nM
Compound 3 ended at the assay's limit; the forecaster's own chance of this, stated with the estimate: 70%; the middle value is on the limit's open side.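

In this assay compound 3 gives < 1000 nM, which is a limit of the assay. Among the compounds shown here, no step among compound 1, compound 2 and compound 3 can be read. How these three compounds truly compare stays open, as the data show only this: the limit of < 1000 nM in this assay, at which 3 of the 3 values shown sit.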